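Replacing the end group of compound 1

The compounds below may be only part of what the source reports. "The series", "measured", "known", "first", "only" and "open" are said of these compounds alone.

In a functional assay on the whole organism for antagonist activity, with Rattus norvegicus as the target (a lower number here means that less compound is needed, a higher number that more compound is needed for the effect), compound 1 `CN1CCN(C(=O)CCCOc2cc(C(=O)N3CCCCc4sccc43)ccc2NC(=O)c2ccccc2-c2ccccc2)CC1` gives 0.03 mg/kg and compound 2 `CN1CCCN(CCCOc2cc(C(=O)N3CCCCc4sccc43)ccc2NC(=O)c2ccccc2-c2ccccc2)CC1` gives 0.03 mg/kg as its dose, so the two stand level. Compound 3 `CCN(CC)C1CCN(C(=O)CCCOc2cc(C(=O)N3CCCCc4sccc43)ccc2NC(=O)c2ccccc2-c2ccccc2)CC1` keeps the core of compound 1 and alters one group on a carbonyl carbon, as counted here 4-(diethylamino)piperidin-1-yl in place of 4-methylpiperazin-1-yl on a carbonyl carbon in full. For the measured compounds named here, one measured step bears on this, and it is small: no change at the digits printed from compound 1 to compound 2 (within the scatter) when 4-methyl-1,4-diazepan-1-yl stands in place of (4-methylpiperazin-1-yl)carbonyl. Going by the values given here, no measured compound carries 4-(diethylamino)piperidin-1-yl, so this evidence is indirect and the range must stay wide. No step beyond the scatter is therefore expected in this assay and the estimated change is a 1.3-fold higher number from compound 1 to compound 3 (0.12 log units; within the scatter) at most modest in size. Compound 3 is expected at about 0.04 mg/kg with an estimated range from 0.015 mg/kg to 0.12 mg/kg once measured.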

Compound 3, dose for 50% inhibition: 0.01 mg/kg
Compound 3: middle estimate off by 4.0-fold (0.60 log units), on the high side; the whole stated range lies above it.
By their numbers in this assay, from the lowest: compound 3; then compounds 1 and 2 (each within the scatter of the next).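

Swapping 4-methylpiperazin-1-yl for 4-(diethylamino)piperidin-1-yl on the carbonyl carbon gives a 3.0-fold lower number from compound 1 to compound 3 (0.48 log units; beyond the scatter) in this assay. For the compounds shown here, the only earlier step at this end of the molecule, no change at the digits printed from compound 1 to compound 2 (within the scatter), stayed within the scatter, so this is the first sign that the end group can shift the dose needed, and the entering group carries more carbon atoms while keeping the same counts of hydrogen-bond donors and acceptors. No measurement shown here explains why the number falls.

As far as these compounds go, it remains open whether the lower number belongs to the diethylamino group or to the piperidine ring itself. A 4-(dimethylamino)piperidin-1-yl group or a plain piperidin-1-yl group on the same carbonyl carbon would help separate these two parts.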